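Cytotoxicity of a pyrimidine series: varying the pendant phenyl ring

The source may report more compounds than this note shows. Statements on the series, on what has been measured and on what is new or still open speak of the compounds shown alone.

Compounds measured in a toxicity assay on MT4 cells (Homo sapiens) for cytotoxicity, read by MTT assay (a lower number here means that less compound is tolerated, a higher number that more compound is tolerated), so far:
compound 1, `Cc1cc(-c2ccccc2F)cc(C)c1Oc1cc(N)nc(Nc2ccc(C#N)cc2)n1`, 29300 nM
compound 2, `Cc1cc(-c2cccc(F)c2)cc(C)c1Oc1cc(N)nc(Nc2ccc(C#N)cc2)n1`, 24700 nM
compound 3, `COc1cccc(-c2cc(C)c(Oc3cc(N)nc(Nc4ccc(C#N)cc4)n3)c(C)c2)c1`, 19300 nM

Among these three, compound 2 sits in the middle: compared with compound 1 it shows a 1.2-fold lower number from compound 1 to compound 2 (0.07 log units; within the scatter), and compared with compound 3 it shows a 1.3-fold lower number from compound 2 to compound 3 (0.11 log units; within the scatter). The step of a 1.5-fold lower number from compound 1 to compound 3 (0.18 log units; within the scatter) is likewise small. All three compounds therefore share one tolerated level, with no ordering among them.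

Compound 4, `Cc1cc(-c2ccc(C#N)c(C#N)c2)cc(C)c1Oc1cc(N)nc(Nc2ccc(C#N)cc2)n1`, has not yet been measured. It differs from compound 2 in one place: 3,4-dicyanophenyl in place of 3-fluorophenyl on an aromatic carbon. The measured steps all concern changes on the same pendant phenyl ring, swapping a fluoro between two positions or replacing fluoro by methoxy, and none moved the number beyond the scatter. The change to compound 4 is larger in kind, but nothing measured points to a shift in either direction. The expectation is that the step of a 1.0-fold lower number from compound 2 to compound 4 (0.01 log units; within the scatter) stays within the scatter, and compound 4 is estimated at 24000 nM, with a range from 9000 nM to 65000 nM.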

Compound 4, half-maximal cytotoxic concentration: 17600 nM
Beside the measured number, compound 4's estimate is 1.4-fold (0.13 log units) above it; the range from low to high includes it.
By their numbers in this assay, from the lowest: compounds 4, 3, 2 and 1 (each within the scatter of the next).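

Replacing 3-fluorophenyl with the larger 3,4-dicyanophenyl, which brings two nitrile groups and two hydrogen-bond acceptors, is a bigger change than any earlier one, yet this assay gives a 1.4-fold lower number from compound 2 to compound 4 (0.15 log units; within the scatter). The other two comparisons agree, with a 1.1-fold lower number from compound 3 to compound 4 (0.04 log units; within the scatter) and a 1.7-fold lower number from compound 1 to compound 4 (0.22 log units; within the scatter), so all four compounds share one level and none goes against this flat picture at this position. No supporting measurement is available to explain why the number stays within the scatter.

As far as these compounds go, what remains open is whether a group carrying a net charge, such as an amine or a carboxylic acid on this phenyl ring, would move the number beyond the scatter. From the compounds shown here alone, it is also open whether a longer chain in place of the ring would do so.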